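A few compounds are considered here, and "the series" means these few. Any claim that something is new, unique, unknown or untested is made for them only; others in the source may bear on it.

Measured in a functional assay on A549 cells (Homo sapiens) for cytotoxicity, read by MTT assay; a higher number here means a weaker inhibitor, a lower number a stronger inhibitor:
- compound 1 `CCn1cc(-c2nnc(COc3ccc4ccccc4c3)o2)c(=O)c2cc(F)c(N3CCNCC3)cc21` gives 80.2 ug/mL
- compound 2 `O=c1c(-c2nnc(-c3ccc(Nc4ccccc4)cc3)o2)cn(C2CC2)c2cc(N3CCNCC3)c(F)cc12` gives 52 ug/mL

These two values lie within the usual scatter of each other, so compound 1 stands level with compound 2 and no ranking can be drawn. Going by the values given here, the two compounds are not separated by a single change, so no measured step is available to guide the next comparison.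

Compound 3 `CCn1cc(-c2nnc(COc3ccccc3)o2)c(=O)c2cc(F)c(N3CCNCC3)cc21` carries phenyl in place of naphthalen-2-yl on an oxygen on a saturated carbon. The data give no size or direction for this change, so no shift beyond the scatter is expected in this assay, and the estimate stays anchored on compound 1 at 80.2 ug/mL as the closest measured structure. The expected step (a 1.1-fold higher number from compound 1 to compound 3 (0.03 log units; within the scatter)) is small. Compound 3 is expected at 85 ug/mL (estimated range 42 ug/mL to 170 ug/mL).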

Compound 3, half-maximal inhibitory concentration: 76.8 ug/mL
Compound 3: the middle estimate sits 1.1-fold (0.04 log units) above what was measured; the range from low to high includes it.
By their numbers in this assay, from the lowest: compounds 2, 3 and 1 (each within the scatter of the next).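

In this assay, the series now has its first measured single-place step: phenyl in place of naphthalen-2-yl on an oxygen on a saturated carbon reads as a 1.0-fold lower number from compound 1 to compound 3 (0.02 log units; within the scatter) and gives no separation between the two compounds. At this place, then, going from 10 heavy atoms and two six-membered aromatic rings to 6 heavy atoms and one such ring does not move the number beyond the scatter, so the second ring of the naphthalen-2-yl group shows no measurable contribution here. No supporting measurement accounts for this result.

Open, on these data alone, is whether a group without an aromatic ring on the same oxygen, such as cyclohexyl or a short alkyl chain, would also stay level with compound 3. Equally open, as far as these compounds go, is whether a chlorine, a methoxy group or an amine on the phenyl ring of compound 3 would separate from it.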